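The source may report more compounds than this note shows. Statements on the series, on what has been measured and on what is new or still open speak of the compounds shown alone.

Three compounds share one core and differ only in the aryl group on a saturated ring carbon. In a functional assay on BGC-823 cells (Homo sapiens) for antiproliferative activity, read by MTT assay, tested at 1 uM (a higher number here means a stronger effect of the compound at the concentration tested, a lower number a weaker effect), compound 1 `COc1cc(C2=NN(C(C)=O)C(c3cccc(F)c3)O2)cc(OC)c1OC` gives 14.7%, compound 2 `COc1cc(C2=NN(C(C)=O)C(c3ccc(F)cc3)O2)cc(OC)c1OC` gives -0.4%, and compound 3 `COc1cc(C2=NN(C(C)=O)C(c3cccc(OC)c3OC)O2)cc(OC)c1OC` gives 3.8%. Compound 3 thus stands second highest of the three numbers; its nearest neighbour is compound 2, the step of a number 4.2 percentage points higher from compound 2 to compound 3 (within the scatter) lying within the scatter, while a number 10.9 percentage points lower from compound 1 to compound 3 (beyond the scatter) lies beyond it.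

Compound 4 `COc1ccc(OC)c(C2OC(c3cc(OC)c(OC)c(OC)c3)=NN2C(C)=O)c1` is reached from compound 3 by the change (2,5-dimethoxyphenyl in place of 2,3-dimethoxyphenyl on a saturated ring carbon). For the measured compounds named here, two measured steps bear on such a rearrangement of ring substituents: a number 15.1 percentage points lower from compound 1 to compound 2 (beyond the scatter), a modest but real loss, and a number 4.2 percentage points higher from compound 2 to compound 3 (within the scatter), which left the number within the scatter. Moving a group around the aryl ring has therefore produced either a modest drop or nothing clear, and no step among these compounds has raised the read-out beyond the scatter. Compound 4 is accordingly expected to give about 5% in this assay , between -10% and 20%, which corresponds to an expected step of a number 1.2 percentage points higher from compound 3 to compound 4 (within the scatter), within the scatter.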

Compound 4, a percentage reported as inhibition, at one concentration (the size of the read-out at that concentration, not a potency): 0.4%
For compound 4 the middle estimate is 4.6 percentage points above the measured one, and the stated range covers the measured number.
By their numbers in this assay, from the lowest: compounds 2, 4 and 3 (each within the scatter of the next); then compound 1.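

In this assay, the exchange of 2,3-dimethoxyphenyl for 2,5-dimethoxyphenyl on the saturated ring carbon gives a number 3.4 percentage points lower from compound 3 to compound 4 (within the scatter), so this rearrangement of the two methoxy groups has no clear effect on the read-out. The comparison with the fluorinated compounds gives a number 0.8 percentage points higher from compound 2 to compound 4 (within the scatter) and a number 14.3 percentage points lower from compound 1 to compound 4 (beyond the scatter), which places compound 4 with compound 2 and compound 3 and leaves compound 1, with its 3-fluorophenyl group, as the only one of the four set apart from the others. No evidence is available to explain these results.

As far as these compounds go, whether an aryl group carrying an amine or a carboxylic acid would give a higher read-out than compound 1 remains open. The single concentration also leaves the potency of all four compounds open.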